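Trifluoromethyl for dicyanoethenyl: an expected step in potency

The compounds below may be only part of what the source reports. "The series", "measured", "known", "first", "only" and "open" are said of these compounds alone.

Of the compounds shown here, three sharing one core have been measured in a functional assay (aorta) with Rattus norvegicus as the target; a lower number here means a less potent compound, a higher number a more potent compound, by a factor of ten per unit of this negative logarithm. The bare compound 1 `CC1(C)C=C(n2ccccc2=O)c2ccccc2O1` gives 5.43. Compound 2 `Cc1ccccc1C(=O)c1ccc2c(c1)C(n1ccccc1=O)=CC(C)(C)O2` bears a (2-methylphenyl)carbonyl on an aromatic carbon and gives 6.83, while compound 3 `CC1(C)C=C(n2ccccc2=O)c2cc(C=C(C#N)C#N)ccc2O1` bears a 2,2-dicyanoethenyl on that aromatic carbon and gives 6.95. Compound 3 holds the highest of the three numbers, but it cannot be ranked above compound 2, because a number 0.12 log units higher from compound 2 to compound 3 (within the scatter) lies within the scatter; its separation from compound 1 is clear, since a number 1.52 log units higher from compound 1 to compound 3 (beyond the scatter).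

Compound 4 `CC1(C)C=C(n2ccccc2=O)c2cc(C(F)(F)F)ccc2O1` has not been measured. It differs from compound 3 in one place: trifluoromethyl in place of 2,2-dicyanoethenyl on an aromatic carbon. For the measured compounds named here, two measured steps bear on this change. The gains a number 1.40 log units higher from compound 1 to compound 2 (beyond the scatter) and a number 1.52 log units higher from compound 1 to compound 3 (beyond the scatter) show that two quite different groups on that aromatic carbon each lift the number by a large amount, and a number 0.12 log units higher from compound 2 to compound 3 (within the scatter) shows that the two groups are indistinguishable. Whether a group of only four heavy atoms keeps such a gain is not known from these data, so a partial loss is the cautious expectation.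

Compound 4 is therefore estimated at 6.3, with a range from 5.5 to 7. The expected step is a number 0.65 log units lower from compound 3 to compound 4 (beyond the scatter), a moderate fall that still leaves compound 4 above compound 1.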

Compound 4, logarithm of the reciprocal of the active concentration, log(1/C): 7.61
For compound 4 the middle estimate is 1.31 log units below the measured one; the whole stated range lies below it.
By their numbers in this assay, from the lowest: compound 1; then compounds 2 and 3 (each within the scatter of the next); then compound 4.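

On this aromatic carbon, the largest gain over hydrogen among the compounds shown comes from trifluoromethyl, with a number 2.18 log units higher from compound 1 to compound 4 (beyond the scatter), so a group of 4 heavy atoms is enough to raise the number far above that of the bare core. Compounds 2 and 3 could not be told apart, but trifluoromethyl stands clear of both, with a number 0.66 log units higher from compound 3 to compound 4 (beyond the scatter) and a number 0.78 log units higher from compound 2 to compound 4 (beyond the scatter), so the position does discriminate among groups that give a large gain. Trifluoromethyl has no hydrogen-bond acceptors by the count used here and contains neither the nitrile groups of 2,2-dicyanoethenyl nor the carbonyl and second aromatic ring of (2-methylphenyl)carbonyl, so none of these features is required for a high number in this assay.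

Nothing among the data shown accounts for why trifluoromethyl gives the higher number. As far as these compounds go, it remains open whether a single chlorine, a methoxy group, a nitrile, an amine or a carboxylic acid on this aromatic carbon would match trifluoromethyl, and whether trifluoromethyl would give a similar gain on any other aromatic carbon of the shared core.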